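This account rests on a few compounds, and the source may have more. Where it says the series, first, only, none or still open, it means among the compounds named here.

Compound 1 `Nc1nc2cc(-c3nn(CCC(=O)NO)c4ncnc(N)c34)ccc2o1` is the starting point of this series. In a functional assay on MCF7 cells (Homo sapiens) for inhibition, read by MTT assay, with a stated time of 72 h (on this read-out higher numbers stand for weaker inhibition and lower numbers for stronger inhibition), compound 1 gives > 100000 nM, which is a limit of the assay rather than a number. Compound 2 `Nc1nc2cc(-c3nn(CCCCCCCCC(=O)NO)c4ncnc(N)c34)ccc2o1` carries a longer chain ending in the same group, and in this assay compound 2 gives 42100 nM. That change amounts to an at least 2.3-fold lower number from compound 1 to compound 2 (0.37 log units; beyond the scatter). Compound 2 therefore stands as the only number shown so far; the other value is a limit (the limit of > 100000 nM in this assay, at which 1 of the 2 values shown sits). Compound 3 `Nc1nc2cc(-c3nn(CCCCCCC(=O)NO)c4ncnc(N)c34)ccc2o1` is the next step, and its difference from compound 2 is hydroxycarbamoyl in place of 2-(hydroxycarbamoyl)ethyl on a saturated chain carbon, six bonds along the chain from an aromatic nitrogen. This shortens the chain back toward compound 1 without reaching it. Among the compounds with values here, the only measured step that bears on it is an at least 2.3-fold lower number from compound 1 to compound 2 (0.37 log units; beyond the scatter), where lengthening the chain lowered the number beyond the scatter. Shortening it is expected to move the number back up, but by less than the whole of that step, since compound 3 keeps much of the added length. The expected step is a 1.7-fold higher number from compound 2 to compound 3 (0.22 log units; within the scatter). Compound 3 is expected to give 70000 nM, with a range from 30000 nM to 150000 nM, and a real chance that only a limit is returned.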

Compound 3, half-maximal inhibitory concentration: 11900 nM
For compound 3 the middle estimate is 5.9-fold (0.77 log units) above the measured one; measured number outside the range, below it.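

In this assay, chain length does not act in one direction: shortening the longest chain shown gives a 3.5-fold lower number from compound 2 to compound 3 (0.55 log units; beyond the scatter), so adding length helps only up to a point. Measured against the shortest chain, the result is an at least 8.4-fold lower number from compound 1 to compound 3 (0.92 log units; beyond the scatter), which places the intermediate chain of compound 3 at the lowest number of the three, with both steps beyond the scatter, and compound 2 goes against any simple rule that longer is better. Compound 1 gives only a limit of the assay, so the second step sets a minimum size and not an exact one: the limit of > 100000 nM in this assay, at which 1 of the 3 values shown sits.

Chains of intermediate lengths, between those of compound 1 and compound 3 or between those of compound 3 and compound 2, would show where the lowest number really lies, as three lengths can only outline the trend. Going by these compounds, it also remains open whether the hydroxycarbamoyl end is required, which a carboxylic acid or a primary amide at the end of the same chain would test, and these numbers do not explain why the trend turns.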